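The source may hold more compounds than are shown below. What is called first, only, known or untested is meant among the compounds shown, and "the series" means these compounds.

Compound 1 `COc1cc(NC(C)CCCNC(=O)NCc2ccccc2)c2ncccc2c1` and compound 2 `COc1cc(NC(C)CCCNC(=O)NC2CCCCC2)c2ncccc2c1` share one core and differ on an amide-type nitrogen, where benzyl in compound 1 is exchanged for cyclohexyl in compound 2. In a functional assay on HeLa cells (Homo sapiens), read by MTT assay, with a stated time of 72 h (a higher number here means a weaker inhibitor, a lower number a stronger inhibitor), compound 1 gives 15000 nM. In this assay compound 2 gives only a limit of the assay, > 100000 nM. The step of an at least 6.6-fold higher number from compound 1 to compound 2 (0.82 log units; beyond the scatter) is therefore known only as a lower bound, because compound 2 sits at the limit of > 100000 nM in this assay, at which 1 of the 2 values shown sits. Compound 3 `CCN(CC)C(=O)NCCCC(C)Nc1cc(OC)cc2cccnc12` differs from compound 2 in a different place: diethylamino in place of cyclohexylamino on a carbonyl carbon. Among the measured compounds shown here, no measured step touches that carbonyl carbon, so the one known step, from benzyl to cyclohexyl on the amide-type nitrogen, bears on it only as a sign that this region tolerates change poorly. With compound 2 already at a limit, compound 3 is expected to remain weak in this assay, with a step of a number no higher from compound 2 to compound 3 (the limit leaves the size open). The estimate for compound 3 is 100000 nM, within 30000 nM to 300000 nM, and a further limit rather than a number is considered likely.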

Compound 3, half-maximal inhibitory concentration: 58000 nM
The estimate for compound 3 lay 1.7-fold (0.24 log units) above the measured number; the range from low to high includes it.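

Exchanging benzylamino for diethylamino on the carbonyl carbon gives a 3.9-fold higher number from compound 1 to compound 3 (0.59 log units; beyond the scatter) in this assay, a fully sized step where the earlier one was known only as a bound, and it shows that a group with no ring at this place can still give a measured number. Against cyclohexylamino the step reads an at least 1.7-fold lower number from compound 2 to compound 3 (0.23 log units; that floor lies within the scatter), a floor that does not by itself separate the two groups. That floor cannot be tightened, because compound 2 stands at a limit: the limit of > 100000 nM in this assay, at which 1 of the 3 values shown sits.

Open, going by these compounds, is how a phenethylamino or a morpholine group would read on this carbonyl carbon. Also open, on these data alone, is whether dimethylamino, with its shorter alkyl groups, would follow diethylamino.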